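Swapping Hydroxy for Chloro on Compound 1

This account rests on a few compounds, and the source may have more. Where it says the series, first, only, none or still open, it means among the compounds named here.

Among the measured compounds shown here, in a functional assay on the whole organism (Hindlimb, strain albino) with Mus musculus as the target, in the maximal electroshock model, with a stated time of 0.5 h (a lower number here means that less compound is needed, a higher number that more compound is needed for the effect), compound 1 (`CC(=O)N1N=C(Nc2nc3ccc(C)cc3s2)CC1c1ccc(O)cc1`) gives 50.2 umol/kg, the lowest of the three numbers measured so far. Compound 2 (`CC(=O)N1N=C(Nc2nc3ccc([N+](=O)[O-])cc3s2)CC1c1ccc(O)cc1`) gives 162 umol/kg, and compound 3 (`O=C(/C=C/c1ccccc1)Nc1nc2ccc(Cl)cc2s1`) gives 425 umol/kg. Compound 3 differs from the other two in more than one place, so its number offers no clean comparison here.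

Compound 4 (`CC(=O)N1N=C(Nc2nc3ccc(C)cc3s2)CC1c1ccc(Cl)cc1`) has not yet been measured in this assay. It keeps the core of compound 1 and exchanges one group: chloro in place of hydroxy on an aromatic carbon. Put simply, chloro takes the place of hydroxy on an aromatic carbon, turning 4-hydroxyphenyl into 4-chlorophenyl.

For the measured compounds named here, only one measured step involves a single change: a 3.2-fold higher number from compound 1 to compound 2 (0.51 log units; beyond the scatter). There, nitro replaces methyl, so the hydroxy group stays untouched. This step therefore speaks only to size, showing that one exchange on this core can move the number beyond the scatter. Going by the values given here, no measured compound shows what replacing hydroxy does, so neither direction can be favoured, and no step beyond the scatter is predicted.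

The estimate amounts to a 1.0-fold lower number from compound 1 to compound 4 (0.00 log units; within the scatter), which is an expected step with no preferred direction. Compound 4 is expected at about 50 umol/kg, with an estimated range from 18 umol/kg to 140 umol/kg.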

Compound 4, dose for half-maximal effect: 25.5 umol/kg
For compound 4 the middle estimate is 2.0-fold (0.29 log units) above the measured one; the range from low to high includes it.
By their numbers in this assay, from the lowest: compounds 4 and 1 (each within the scatter of the next); then compound 2; then compound 3.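

On the 4-hydroxyphenyl group of this core, this assay now has its first exchange, and the move to 4-chlorophenyl gives a 2.0-fold lower number from compound 1 to compound 4 (0.29 log units; within the scatter) within the scatter. Hydroxy counts as a hydrogen-bond donor and acceptor while chloro counts as neither, yet compound 4 and compound 1 cannot be told apart here, so on this core and in this whole-animal test the number does not depend on keeping hydroxy, whereas the exchange at the other site (a 3.2-fold higher number from compound 1 to compound 2 (0.51 log units; beyond the scatter)) lies beyond the scatter. No measurement is available that would explain this outcome.

On these data alone, this conclusion rests on a single pair of compounds, so it remains open how a fluoro group, a methoxy group, an amine or a carboxylic acid would read in the same place on the ring. As far as these compounds go, it also remains open whether chloro in place of hydroxy would leave the number just as undisturbed on the nitro-bearing compound 2, where the rest of the molecule differs from compound 1 in one place.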